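Swapping a Thiadiazole for a Thiophene on a Sulfoxide Linker

The source may report more compounds than this note shows. Statements on the series, on what has been measured and on what is new or still open speak of the compounds shown alone.

Measured compounds:
Compound 1 `[O-][S+](Cc1cccs1)C(c1ccc(Cl)cc1)c1ccc(Cl)cc1`: 7200 nM
Compound 2 `Cc1nnc(C[S+]([O-])C(c2ccccc2)c2ccccc2)s1`: "not active" (no number reported)
Compound 3 `Cc1ccc(C(c2ccc(C)cc2)[S+]([O-])Cc2cccs2)cc1`: 5800 nM

The read-out here is an assay on HEK293 cells for inhibition of sodium-dependent dopamine transporter (Homo sapiens), read by scintillation counting, with stated times of 5 min and 1 min; a higher number here means a weaker inhibitor, a lower number a stronger inhibitor. Compound 1 and compound 3, which both carry a (thiophen-2-yl)methyl arm on the sulfoxide, are weak inhibitors, and their two values lie within the usual scatter of each other. Compound 2 stands apart: in this assay compound 2 was reported only as not active, with no number given. Compound 4 `[O-][S+](Cc1ccsc1)C(c1ccccc1)c1ccccc1` differs from compound 2 in a single place: thiophen-3-yl in place of 5-methyl-1,3,4-thiadiazol-2-yl on a saturated chain carbon bound to a sulfur. Among the measured compounds shown here, no measured pair shows this exact change, so the size of the step cannot be read from the data. Given that compound 1 gives 7200 nM with a related arm, compound 4 is expected to show weak but measurable inhibition, estimated at 12000 nM (range 4000 nM to 40000 nM).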

Compound 4, half-maximal inhibitory concentration: 3000 nM
For compound 4 the middle estimate is 4.0-fold (0.60 log units) above the measured one, outside the stated range (below it).
By their numbers in this assay, from the lowest: compounds 4, 3 and 1 (each within the scatter of the next, the first and the last beyond it).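

In this assay, among the compounds shown here, compound 2 has no number, so no step from compound 2 to compound 4 can be read. Whether the change of arm alone separates these two compounds stays open, and no further data explain the result.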